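The compounds below may be only part of what the source reports. "The series", "measured", "known", "first", "only" and "open" are said of these compounds alone.

Measured so far:
compound 1, `N=C(NC(=N)NC1CCCC1)Nc1ccc(C(F)(F)F)cc1` — 7300 nM
compound 2, `CCCCCCCNC(=N)NC(=N)Nc1ccc(F)c(F)c1` — 6400 nM

Going by the values given here, in an ADME assay on HUVEC cells (Homo sapiens) for cytotoxicity, read by MTT assay, with a stated time of 72 h (on this read-out lower numbers stand for stronger inhibition and higher numbers for weaker inhibition), compound 1 gives 7300 nM, the higher of the two numbers so far; compound 2 gives 6400 nM, and the two lie within the scatter of each other, so they cannot be told apart on this read-out. The unmeasured compound 3, `CC(C)CNC(=N)NC(=N)Nc1ccc(C(F)(F)F)cc1`, shares its core with compound 1 and differs from it in one place: isobutyl in place of cyclopentyl on an amine nitrogen. Among the compounds with values here, no step between measured compounds bears on this change, so the account rests on compound 1 alone and on the change itself. The step from compound 1 to compound 3 is expected to be small, a 1.1-fold higher number from compound 1 to compound 3 (0.04 log units; within the scatter), most likely not beyond the scatter, and if anything toward a slightly higher number. Compound 3 is therefore estimated at 8000 nM, within a range from 3500 nM to 18000 nM.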

Compound 3, half-maximal inhibitory concentration: 8500 nM
The estimate for compound 3 lay 1.1-fold (0.03 log units) below the measured number, within the range that was stated.
By their numbers in this assay, from the lowest: compounds 2, 1 and 3 (each within the scatter of the next).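

The step at this position in this assay is a 1.2-fold higher number from compound 1 to compound 3 (0.07 log units; within the scatter), with isobutyl in place of cyclopentyl on an amine nitrogen. Going by these compounds alone, it is the first direct comparison at this nitrogen, and it shows that the five-membered carbon ring of cyclopentyl can give way to ringless isobutyl while compound 1 and compound 3 remain indistinguishable on this read-out. Nothing available here offers an explanation of this result.

Going by these compounds, whether a group of another kind on this nitrogen, such as a phenyl ring, a carboxylic acid or a chain ending in an amine, would stand apart from compound 1 remains open. On these data alone, compound 2 carries a heptyl chain but differs from compound 1 in more than one place, so the effect of a longer chain at this position also remains open.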